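This account rests on a few compounds, and the source may have more. Where it says the series, first, only, none or still open, it means among the compounds named here.

Measured in an ADME assay on HepG2 cells (Homo sapiens) for cytotoxicity, read by luminescence, CellTiter-Glo and ATP content, with a stated time of 72 h; a higher number here means that more compound is needed for the effect, a lower number that less compound is needed: compound 1 `COc1cccc(CNCCCNc2ccnc3cc(-c4ccc(F)cc4)ccc23)c1O` gives 6840 nM; compound 2 `COc1cccc(CNCCCNc2ccnc3cc(-c4ccc(C(C)(C)C)cc4)ccc23)c1O` gives 690 nM; compound 3 `COc1cccc(Oc2ccc3c(NCCCNCc4ccco4)ccnc3c2)c1` gives 15500 nM.

Compound 3 gives the highest number of the three in this assay; compound 1 sits below it, compound 2 well below. Among the measured compounds shown here, the only recorded step, a 9.9-fold lower number from compound 1 to compound 2 (1.00 log units; beyond the scatter), concerns a swap on an aromatic carbon elsewhere in the molecule and does not bear on the present change. Compound 4 `COc1cccc(Oc2ccc3c(NCCCNCc4cccc(OC)c4O)ccnc3c2)c1` differs from compound 3 by 2-hydroxy-3-methoxyphenyl in place of furan-2-yl on a saturated chain carbon bound to an amine nitrogen. For the measured compounds named here, compound 4 thereby carries the same 2-hydroxy-3-methoxybenzylamino end as compounds 1 and 2, but on the core of compound 3; no measured pair isolates this change, and the lower values of compounds 1 and 2 come with a different core. A lowering of about a 1.9-fold lower number from compound 3 to compound 4 (0.29 log units; within the scatter) is expected, with wide uncertainty. Compound 4 is estimated at 8000 nM, range 3000 nM to 22000 nM.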

Compound 4, half-maximal effective concentration: 5300 nM
Compound 4: the middle estimate sits 1.5-fold (0.18 log units) above what was measured; low and high end bracket the measured number.
By their numbers in this assay, from the lowest: compound 2; then compounds 4 and 1 (each within the scatter of the next); then compound 3.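

In this assay, 2-hydroxy-3-methoxyphenyl in place of furan-2-yl on a saturated chain carbon bound to an amine nitrogen gives a 2.9-fold lower number from compound 3 to compound 4 (0.47 log units; beyond the scatter). With that end held fixed, 3-methoxyphenoxy in place of 4-(tert-butyl)phenyl on an aromatic carbon gives a 7.7-fold higher number from compound 2 to compound 4 (0.89 log units; beyond the scatter), whereas 3-methoxyphenoxy in place of 4-fluorophenyl gives a 1.3-fold lower number from compound 1 to compound 4 (0.11 log units; within the scatter). No supporting evidence accounts for these steps.

Furan-2-yl appears here only with 3-methoxyphenoxy, so whether the swap carries over to the cores of compound 1 and compound 2 remains open. Also open, on these data alone, is how unsubstituted benzyl or pyridin-2-ylmethyl would compare with 2-hydroxy-3-methoxybenzyl.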